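Swapping cyclopropyl for isopropyl on a chloro compound

The source may report more compounds than this note shows. Statements on the series, on what has been measured and on what is new or still open speak of the compounds shown alone.

Compound 1 `N#Cc1c(N2CCC(c3ccccc3)CC2)ccn(CC2CC2)c1=O`: 18 mL/min/kg
Compound 2 `O=c1c(Cl)c(N2CCC(c3ccccc3)CC2)ccn1CC1CC1`: 24 mL/min/kg

For the measured compounds named here, in an ADME assay on the whole organism (strain Sprague-Dawley) for pharmacokinetics, with Rattus norvegicus as the target, at a dose of 2.5 mg/kg by the intravenous route (a higher number here means faster removal of the compound, a lower number slower removal), compound 2 gives 24 mL/min/kg, within the scatter of compound 1 at 18 mL/min/kg, the only other measured compound. Compound 3 `CC(C)Cn1ccc(N2CCC(c3ccccc3)CC2)c(Cl)c1=O` has isopropyl in place of cyclopropyl on a saturated chain carbon bound to an aromatic nitrogen. Going by the values given here, the one measured step, a 1.3-fold higher number from compound 1 to compound 2 (0.12 log units; within the scatter), puts chloro in place of cyano on an aromatic carbon, so it does not test this change and offers only a weak guide. With no direct evidence, the expected result is a 1.1-fold higher number from compound 2 to compound 3 (0.03 log units; within the scatter), which would be no shift beyond the scatter. For compound 3 the estimated clearance is 26 mL/min/kg, with an expected range of 13 mL/min/kg to 50 mL/min/kg.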

Compound 3, clearance: 13 mL/min/kg
Beside the measured number, compound 3's estimate is 2.0-fold (0.30 log units) above it, and the stated range covers the measured number.
By their numbers in this assay, from the lowest: compounds 3, 1 and 2 (each within the scatter of the next).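

For the compounds shown here, this is the first change at this position, the saturated chain carbon bound to an aromatic nitrogen. In this assay, replacing cyclopropyl with isopropyl opens the three-membered ring, yet the result (a 1.8-fold lower number from compound 2 to compound 3 (0.27 log units; within the scatter)) stays within the usual scatter, so the ring is not shown to matter for clearance here. Nothing shown offers an explanation for this result. Still open, going by these compounds, is whether a larger change at this place, such as a longer chain or an added amine or carboxylic acid, would move clearance beyond the scatter. On these data alone, it is also open whether the same swap would behave alike on the nitrile-bearing compound 1.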